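This account rests on a few compounds, and the source may have more. Where it says the series, first, only, none or still open, it means among the compounds named here.

Measured compounds, all in an assay for inhibition of Indoleamine 2,3-dioxygenase 1 (Homo sapiens), read by fluorescence, with a stated time of 1 h; a higher number here means a weaker inhibitor, a lower number a stronger inhibitor:

compound 1 `CC1(C(=O)NCCSc2nonc2/C(=N/O)Nc2ccc(F)c(C(F)F)c2)CCN1` gives 360 nM
compound 2 `C[C@H](CSc1nonc1/C(=N/O)Nc1ccc(F)c(Br)c1)NC(=O)CS(N)(=O)=O` gives 110 nM
compound 3 `COc1nonc1/C(=N/O)Nc1ccc(F)c(Br)c1` gives 230 nM

Among these three, compound 1 has the highest number in this assay. Compound 3 comes nearest to it, and the gap between the two lies within the usual scatter, so no order between compound 1 and compound 3 can be read from the data. Compound 2 has a lower number, and that gap lies beyond the scatter.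

Compound 4 `CC(C)(O)CC(=O)NCCSc1nonc1/C(=N/O)Nc1ccc(F)c(C(F)F)c1` has not yet been measured. It differs from compound 1 in one place: a group of 5 heavy atoms (4 carbon, 1 oxygen; no ring) in place of a group of 5 heavy atoms (4 carbon, 1 nitrogen; one four-membered non-aromatic ring with 1 hetero atom), on a carbonyl carbon. The rest of the molecule, the shared core and the fluorinated aromatic part, stays the same. For the measured compounds named here, no step between two measured compounds shows this exchange, so nothing in the data says how large its effect is. Given that one small group is swapped for another of like size, the step from compound 1 to compound 4 in this assay is expected to be small, without a clear direction, and likely not beyond the scatter; the expected step is a 1.1-fold higher number from compound 1 to compound 4 (0.05 log units; within the scatter). Compound 4 is therefore estimated to give about 400 nM in this assay, most likely between 150 nM and 1100 nM.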

Compound 4, half-maximal inhibitory concentration: 140 nM
For compound 4 the middle estimate is 2.9-fold (0.46 log units) above the measured one; measured number below the stated range.
By their numbers in this assay, from the lowest: compounds 2, 4, 3 and 1 (each within the scatter of the next, the first and the last beyond it).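

In this assay the group on the carbonyl carbon proves to count: exchanging the group with the four-membered ring for 2-hydroxy-2-methylpropyl gives a 2.6-fold lower number from compound 1 to compound 4 (0.41 log units; beyond the scatter) and so shows that this place does not accept any small group equally. The two groups match in heavy-atom count, hydrogen-bond donors and acceptors, and lack of net charge, so those counts alone do not set the number here. Nothing available explains the difference.

This single exchange changes the ring, the nitrogen and the hydroxy oxygen together, so it cannot show which of them matters. Going by these compounds, whether a carboxylic acid, an open-chain amine or a longer chain on the same carbonyl carbon would lower the number further remains open.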